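Series notes: from compound 2 to compound 3

This account rests on a few compounds, and the source may have more. Where it says the series, first, only, none or still open, it means among the compounds named here.

Measured so far: compound 1 `O=c1nc2oc(C3CC3)c(C#CC3CC3)c2cn1Cc1cn(Cc2ccccc2)nn1`, 290 nM; compound 2 `O=c1nc2oc(CCCCl)c(C#CCCCCl)c2cn1Cc1cn(Cc2ccccc2)nn1`, 17600 nM.

In an ADME assay on WI-38 cells (Homo sapiens) for antiproliferative activity, read by MTT assay, with a stated time of 72 h (a lower number here means a stronger inhibitor, a higher number a weaker inhibitor), compound 2 gives 17600 nM, the highest of the two numbers, while compound 1 gives 290 nM, a gap well beyond the scatter. Compound 3 `O=c1nc2oc(CCCCl)cc2cn1Cc1cn(Cc2ccccc2)nn1` differs from compound 2 by hydrogen in place of 5-chloropent-1-yn-1-yl on an aromatic carbon. Among the compounds with values here, no measured pair shows this change, so the expected step in this assay is a 1.4-fold higher number from compound 2 to compound 3 (0.15 log units; within the scatter), a modest move with no direction claimed beyond the scatter. Compound 3 is expected at 25000 nM, with a range of 6000 nM to 80000 nM.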

Compound 3, half-maximal inhibitory concentration: 5200 nM
Beside the measured number, compound 3's estimate is 4.8-fold (0.68 log units) above it; measured number below the stated range.
By their numbers in this assay, from the lowest: compound 1; then compound 3; then compound 2.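

In this assay, hydrogen in place of 5-chloropent-1-yn-1-yl on this aromatic carbon gives a 3.4-fold lower number from compound 2 to compound 3 (0.53 log units; beyond the scatter). Within the data shown here, this is the first single-place step: with the 3-chloropropyl group held constant, the number does not depend on keeping the alkynyl chain here, and its loss goes with a lower number. No measured evidence explains the step.

Open, as far as these compounds go, is whether the same change holds with the cyclopropyl group of compound 1 in place of 3-chloropropyl. Also open, from the compounds shown here alone, is how a methyl group or an amine-bearing chain on this carbon would read.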